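Working notes: exchange of the 4-nitrophenyl group

The source may hold more compounds than are shown below. What is called first, only, known or untested is meant among the compounds shown, and "the series" means these compounds.

- compound 1 `Cc1cc(=O)c2c(O)c(CN3CCC(Cc4ccccc4)CC3)c(O)c([C@H]3CCN(C)C[C@H]3O)c2o1`: 17%
- compound 2 `Cc1oc2c([C@H]3CCN(C)C[C@H]3O)c(O)cc(O)c2c(=O)c1C(O)c1ccc([N+](=O)[O-])cc1`: 4%

In a functional assay on MCF7 cells (Homo sapiens) for inhibition, read by MTT assay, with a stated time of 48 h, tested at 10 uM (on this read-out higher numbers stand for more inhibition of growth at the one concentration tested and lower numbers for less inhibition of growth), compound 2 gives 4%, the lower of the two numbers, and compound 1 stands higher by more than the usual scatter. Compound 3 `Cc1oc2c([C@H]3CCN(C)C[C@H]3O)c(O)cc(O)c2c(=O)c1C(O)c1ccc(F)c(Br)c1` carries 3-bromo-4-fluorophenyl in place of 4-nitrophenyl on a saturated chain carbon bound to an aromatic carbon and an oxygen on a saturated carbon. For the measured compounds named here, no measured step covers this exchange, so only a small upward move is expected in this assay: the estimated step of a number 6 percentage points higher from compound 2 to compound 3 (within the scatter) stays within the scatter. Compound 3 is expected at 10%, with an estimated range of 2% to 24%.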

Compound 3, percent growth inhibition at one concentration: 14%
The estimate for compound 3 lay 4 percentage points below the measured number, within the range that was stated.
By their numbers in this assay, from the lowest: compounds 2, 3 and 1 (each within the scatter of the next, the first and the last beyond it).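

In this assay, for the compounds shown here, the exchange of 4-nitrophenyl for 3-bromo-4-fluorophenyl on the saturated chain carbon reads as a number 10 percentage points higher from compound 2 to compound 3 (within the scatter) and gives the first step at this position. Compound 2 and compound 3 cannot be told apart here, so these two aromatic groups are interchangeable at this place on this read-out. No measurement at hand bears on why the two compounds read alike.

Going by these compounds, whether a non-aromatic group at this carbon, such as a piperidine amine or a carboxylic acid, would give a step beyond the scatter remains open. On these data alone, the role of the hydroxy group on this carbon also remains open.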